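A few compounds are considered here, and "the series" means these few. Any claim that something is new, unique, unknown or untested is made for them only; others in the source may bear on it.

Compound 1 `CCCc1ncn2c(SC)nncc12` and compound 2 `CSc1nncc2c(C(C)C)ncn12` share one core, while compound 3 `CCc1ncn2c(Nc3cc[nH]n3)nccc12` carries a different substituent on a related core. In a functional assay for inhibition, with Homo sapiens as the target (a lower number here means a stronger inhibitor, a higher number a weaker inhibitor), compound 1 gives only a limit, > 48000 nM. Compound 2 likewise gives only a limit in this assay, > 48000 nM. Within the data shown here, compound 3 gives 36000 nM, the only full number among the three, standing just inside (the limit of > 48000 nM in this assay, at which 2 of the 3 values shown sit). The step that the two limits leave unreadable from compound 1 to compound 2 runs between two limits and so has no readable size. Compound 4 `Cc1ncn2c(Nc3cc[nH]n3)nccc12` differs from compound 3 by hydrogen in place of methyl on a saturated chain carbon bound to an aromatic carbon, which one bond further out reads as ethyl to methyl. Among the measured compounds shown here, no measured step matches this change, so no shift beyond the scatter is foreseen in this assay. Compound 4 is therefore expected to give about 40000 nM, between 18000 nM and 90000 nM, a step of a 1.1-fold higher number from compound 3 to compound 4 (0.05 log units; within the scatter).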

Compound 4, half-maximal inhibitory concentration: 57000 nM
Estimate against measurement, compound 4: 1.4-fold (0.15 log units) below; the range from low to high includes it.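

Ethyl to methyl, on a saturated chain carbon bound to an aromatic carbon, gives in this assay a 1.6-fold higher number from compound 3 to compound 4 (0.20 log units; within the scatter) and so leaves no change beyond the scatter at this place. Among these compounds, this is the first readable step, as the step between the two earlier limits cannot be read. Both values of this pair stay close to where the assay stops giving numbers: the limit of > 48000 nM in this assay, at which 2 of the 4 values shown sit.

From the compounds shown here alone, whether a longer chain such as butyl, or an amine or a carboxylic acid, at this place would give a clearly lower number stays open.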